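Methoxy added to the series' weakest tetrazolyl amide

This account rests on a few compounds, and the source may have more. Where it says the series, first, only, none or still open, it means among the compounds named here.

Compound 3 `Cc1cc(C(=O)Nc2nn[nH]n2)nc(-c2ccccc2)c1` stands lowest of the three compounds measured in a functional assay on the whole organism with Rattus norvegicus as the target, at a dose of 3 mg/kg by the oral route; a higher number here means a stronger effect of the compound at the dose given, a lower number a weaker effect: compound 3 gives 50%, compound 2 `O=C(Nc1nn[nH]n1)c1cccc(-c2ccccc2)n1` gives 74%, and compound 1 `COc1cccc(-c2cc(Cl)cc(C(=O)Nc3nn[nH]n3)n2)c1` gives 95%. Among the measured compounds shown here, the only single-point step available, a number 24 percentage points lower from compound 2 to compound 3 (beyond the scatter), concerns the methyl and not the change now at hand. Compound 4 `COc1cccc(-c2cc(C)cc(C(=O)Nc3nn[nH]n3)n2)c1` differs from compound 3 by methoxy in place of hydrogen on an aromatic carbon. For the measured compounds named here, no measured pair isolates this change; compound 1, the only compound carrying the methoxy, differs from compound 4 in a second place as well, so its high value in this assay can guide only loosely. An upward step of a number 20 percentage points higher from compound 3 to compound 4 (beyond the scatter) is therefore expected, with wide uncertainty. Compound 4 is estimated at 70%, within 45% to 90%.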

Compound 4, a percentage reported as inhibition, in the whole organism at one dose (the size of the read-out at that dose, not a potency): 65%
For compound 4 the middle estimate is 5 percentage points above the measured one; the range from low to high includes it.
By their numbers in this assay, from the lowest: compound 3; then compounds 4 and 2 (each within the scatter of the next); then compound 1.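

In this assay, methoxy in place of hydrogen on an aromatic carbon, meta to a large group, now has a direct reading with the methyl held constant: a number 15 percentage points higher from compound 3 to compound 4 (beyond the scatter), a modest gain. With the methoxy held constant, methyl in place of chloro gives a number 30 percentage points lower from compound 1 to compound 4 (beyond the scatter), so methoxy alone does not carry the high value of compound 1 over to compound 4.

Still open, from the compounds shown here alone, is whether the methoxy step holds with chloro in place of the methyl, and how an amine or a longer ether chain would read at the same place. No measurement here offers an explanation for either step.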